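Chloro in Place of Methyl on a Series at the Limit

The source may report more compounds than this note shows. Statements on the series, on what has been measured and on what is new or still open speak of the compounds shown alone.

Compound 1 `CS(=O)(=O)c1ccc(C(=O)Nc2ccc(Cl)c(-c3nnc4c(Cl)cccn34)c2)c(Cl)c1`: in a functional assay on A549 cells (Homo sapiens) for antiproliferative activity, read by MTT assay, with a stated time of 72 h (a lower number here means a stronger inhibitor, a higher number a weaker inhibitor), compound 1 gives > 100000 nM, a limit of the assay.
Compound 2 `O=C(Nc1ccc(Cl)c(-c2nnc3c(Cl)cccn23)c1)c1ccccc1Cl`: in this assay compound 2 gives > 100000 nM, a limit of the assay.
Compound 3 `Cc1cc(Cl)ccc1C(=O)Nc1ccc(Cl)c(-c2nnc3c(Cl)cccn23)c1`: in this assay compound 3 gives > 100000 nM, a limit of the assay.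

All three measured compounds share one core and differ only in the amide-linked aryl group. Compound 3 stands at the same limit as the other two, so its place on the numbers cannot be set more finely than that; the evidence is simply (the limit of > 100000 nM in this assay, at which 3 of the 3 values shown sit). The step that the two limits leave unreadable from compound 1 to compound 2 and the step that the two limits leave unreadable from compound 2 to compound 3 are both unreadable. Each runs from one limit to another.

Compound 4 `O=C(Nc1ccc(Cl)c(-c2nnc3c(Cl)cccn23)c1)c1ccc(Cl)cc1Cl` carries the change (chloro in place of methyl on an aromatic carbon). Within the data shown here, no measured step bears on this change, since the two steps known are unreadable, and nothing shows that any change on this aryl group moves the read-out off the limit. The expected step that the limit leaves unreadable from compound 3 to compound 4 is therefore none that can be read. Compound 4 is estimated at 200000 nM, between 40000 nM and 1000000 nM, and is expected most likely to come back as a limit again.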

Compound 4, half-maximal inhibitory concentration: 61300 nM
Estimate against measurement, compound 4: 3.3-fold (0.51 log units) above, within the range that was stated.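

In this assay, compound 4, with its 2,4-dichlorophenyl group, is the only compound shown that returns a number rather than a limit: the limit of > 100000 nM in this assay, at which 3 of the 4 values shown sit.

Chloro in place of methyl, on the aromatic carbon ortho to a large group, gives an at least 1.6-fold lower number from compound 3 to compound 4 (0.21 log units; that floor lies within the scatter), while chloro in place of hydrogen gives an at least 1.6-fold lower number from compound 2 to compound 4 (0.21 log units; that floor lies within the scatter) and chloro in place of methylsulfonyl gives an at least 1.6-fold lower number from compound 1 to compound 4 (0.21 log units; that floor lies within the scatter). Each of these steps is only a floor, and each floor lies within the scatter, so the result shows that this amide-linked aryl group can carry the series onto a readable number, but it does not fix the true size of any step or show that the methyl-to-chloro change is a real gain.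

As far as these compounds go, it stays open whether the number for compound 4 needs both chloro groups on this aryl ring, or whether one of them, with a different group in the other place, would serve as well. How the read-out would respond to a fluoro, a methoxy or an amine at the position of the methyl in compound 3 is also unknown.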